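Indole-linked dihydropyrimidine esters: aryl change on the amine

This account rests on a few compounds, and the source may have more. Where it says the series, first, only, none or still open, it means among the compounds named here.

Measured so far:
compound 1 `CCOC(=O)C1=C(C)NC(=S)NC1c1cn(C(=O)CNc2ccc([N+](=O)[O-])c(Cl)c2)c2ccccc12`: 50 ug/mL
compound 2 `CCOC(=O)C1=C(C)NC(=O)NC1c1cn(C(=O)CNc2ccccc2[N+](=O)[O-])c2ccccc12`: 40 ug/mL

In a functional assay on MCF7 cells (Homo sapiens) for cytotoxicity, read by MTT assay, with a stated time of 72 h (on this read-out lower numbers stand for stronger inhibition and higher numbers for weaker inhibition), compound 1 gives 50 ug/mL and compound 2 gives 40 ug/mL. The two values lie within the usual scatter of each other, so compound 1 is not set apart from compound 2 on these numbers. Among the measured compounds shown here, compound 1 and compound 2 differ in more than one place, and no single step between them is available; their values only show that both sit at a similar, weak level of cytotoxicity.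

Compound 3 `CCOC(=O)C1=C(C)NC(=S)NC1c1cn(C(=O)CNc2cccc([N+](=O)[O-])c2)c2ccccc12` is the next compound, not yet measured in this assay. It differs from compound 1 as follows: 3-nitrophenyl in place of 3-chloro-4-nitrophenyl on an amine nitrogen; that is, 3-nitrophenyl in place of 3-chloro-4-nitrophenyl on an amine nitrogen, the amine's other neighbour being a saturated chain carbon. No comparable aryl change has been measured in this series, so there is no shown step to lean on.

The expectation for compound 3 is a step of no change at the digits printed from compound 1 to compound 3 (within the scatter), which is no change beyond the scatter, in either direction. Compound 3 is estimated at 50 ug/mL, in the range 25 ug/mL to 100 ug/mL.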

Compound 3, half-maximal inhibitory concentration: > 1000 ug/mL
Compound 3: no number, only a limit; the forecaster's own chance of this, stated with the estimate: 15%; middle value at least 20-fold (1.30 log units) away from the limit.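

In this assay compound 3 carries a limit of the assay and not a number: the limit of > 1000 ug/mL in this assay, at which 1 of the 3 values shown sits.

Among the compounds shown here, with 3-nitrophenyl in place of 3-chloro-4-nitrophenyl on the amine nitrogen, the read-out shows an at least 20-fold higher number from compound 1 to compound 3 (1.30 log units; beyond the scatter), the first single-place step and a large one. Compounds 1 and 2 differed in more than one place and showed only a similar, weak level, whereas this pair shows that, with the rest of the structure held constant, the aryl group on this amine can decide whether any cytotoxicity is measurable within the range of the assay.

The compounds shown do not separate the loss of the chlorine from the change in where the nitro group stands, so a 4-nitrophenyl or a 3-chlorophenyl on the same amine would be the informative comparison. They also leave open whether the same step holds in compounds with the ring carbonyl of compound 2 in place of the thiocarbonyl of compound 1.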